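Swapping the Dichlorophenyl Group on Compound 3 for Phenylpyridine

This account rests on a few compounds, and the source may have more. Where it says the series, first, only, none or still open, it means among the compounds named here.

- Compound 1 `CC[C@H](C)[C@@H]1C(=O)O[C@H]1C(=O)NCCC(COCc1ccccc1)COCc1ccccc1` gives > 10000 nM as a limit of the assay
- Compound 2 `CC(=O)N[C@@H](CCC(=O)NCCC(COCc1ccccc1)COCc1ccccc1)C(=O)N[C@@H](CC(C)C)B1O[C@@H]2C[C@@H]3C[C@@H](C3(C)C)[C@]2(C)O1` gives 110 nM as its value
- Compound 3 `CC(C)C[C@H](NC(=O)[C@H](CC(=O)NCCC(COCc1ccccc1)COCc1ccccc1)NC(=O)c1cc(Cl)ccc1Cl)B1O[C@@H]2C[C@@H]3C[C@@H](C3(C)C)[C@]2(C)O1` gives 140 nM as its value

In a functional assay on HCT-116 cells (Homo sapiens) for inhibition (on this read-out lower numbers stand for stronger inhibition and higher numbers for weaker inhibition), compound 3 stands at 140 nM and compound 2 at 110 nM and these two numbers lie within the usual scatter of each other. Compound 1 reads > 10000 nM and that is a limit of the assay rather than a number.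

Still unmeasured is compound 4 `CC(C)C[C@H](NC(=O)[C@H](CC(=O)NCCC(COCc1ccccc1)COCc1ccccc1)NC(=O)c1cccc(-c2ccccc2)n1)B1O[C@@H]2C[C@@H]3C[C@@H](C3(C)C)[C@]2(C)O1` which differs from compound 3 in one place. There, 6-phenylpyridin-2-yl takes the place of 2,5-dichlorophenyl on a carbonyl carbon 6-phenylpyridin-2-yl in place of 2,5-dichlorophenyl on a carbonyl carbon and the rest of the structure stays the same.

Within the data shown here, no measured pair shows this change directly. With compound 2 at 110 nM and compound 3 at 140 nM sitting within the scatter, no step beyond the scatter is expected in this assay and no firm direction is claimed. The estimated change is a 1.2-fold lower number from compound 3 to compound 4 (0.07 log units; within the scatter) and it is expected to stay inside the scatter. Among the measured compounds shown here, only two numbers support this expectation, and the range is kept wide. For compound 4 the expected value is 120 nM with an estimated range from 35 nM to 420 nM as the likely span.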

Compound 4, half-maximal inhibitory concentration: 260 nM
The estimate for compound 4 lay 2.2-fold (0.34 log units) below the measured number, within the range that was stated.
By their numbers in this assay, from the lowest: compounds 2, 3 and 4 (each within the scatter of the next, the first and the last beyond it). At a limit, above all of these: compound 1.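

In this assay, the first pair differing in one place gives a 1.9-fold higher number from compound 3 to compound 4 (0.27 log units; within the scatter), so replacing 2,5-dichlorophenyl with 6-phenylpyridin-2-yl on this carbonyl carbon produces no step beyond the scatter. Among these compounds, the position therefore accepts a larger group of 12 heavy atoms in place of 8, with two six-membered aromatic rings instead of one, a hydrogen-bond acceptor where there was none, and no chlorine, while the read-out stays within the scatter; the earlier compounds held no pair that could show this. Nothing available gives a cause for this step or connects it to any measured property of either group.

The compounds shown do not separate the contribution of the ring nitrogen from that of the added phenyl, which a plain phenyl or an unsubstituted pyridin-2-yl on the same carbonyl carbon would address. They also leave open how this position responds to a group of another kind, such as an amine or a carboxylic acid on the aromatic ring, and whether any such group would produce a step beyond the scatter.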